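Removing the amino group from a cis-stilbene retinoid analogue

The compounds below may be only part of what the source reports. "The series", "measured", "known", "first", "only" and "open" are said of these compounds alone.

Within the data shown here, compound 2 `COc1ccc(/C=C\c2ccc3c(c2)C(C)(C)CCC3(C)C)cc1N` provides the only actual number here: in a functional assay on HL-60 cells (Homo sapiens), with a stated time of 48 h (a higher number here means that more compound is needed for the effect, a lower number that less compound is needed), compound 2 gives 50000 nM. Compound 1 `C/C(=C\c1cccc(C(=O)O)c1)c1ccc2c(c1)C(C)(C)CCC2(C)C` gives only a limit of the assay, > 100000 nM, in this assay. Because the limit of > 100000 nM in this assay, at which 1 of the 2 values shown sits, marks that limit, compound 1 offers no number to compare. Compound 3 `COc1ccc(/C=C\c2ccc3c(c2)C(C)(C)CCC3(C)C)cc1` differs from compound 2 by hydrogen in place of amino on an aromatic carbon. Among the measured compounds shown here, no measured step guides this change, so only a modest shift is expected, if any beyond the scatter. Compound 3 is therefore estimated at 60000 nM, within 15000 nM to 150000 nM, an expected step of a 1.2-fold higher number from compound 2 to compound 3 (0.08 log units; within the scatter).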

Compound 3, concentration for half-maximal activity: > 100000 nM
Compound 3: only a limit was reported; the forecaster's own chance of this, stated with the estimate: 30%; at least 1.6-fold (0.22 log units) between middle value and limit.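

In this assay compound 3 gives only a limit of the assay, > 100000 nM. On this aromatic carbon, ortho to a methoxy group, the change reads as an at least 2.0-fold higher number from compound 2 to compound 3 (0.30 log units; that floor lies within the scatter), a floor and not a measured size, so amino is not shown to matter beyond the scatter. The true size of the step stays unreadable because of where the values end: the limit of > 100000 nM in this assay, at which 2 of the 3 values shown sit.

The compounds shown leave open whether a hydroxyl or a methylamino group on this carbon would give a number within the range of the assay.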